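The compounds below may be only part of what the source reports. "The series", "measured", "known", "first", "only" and "open" are said of these compounds alone.

In a functional assay on NALM-6 cells (Homo sapiens) for cytotoxicity, read by luminescence and CellTiter-Glo, with a stated time of 3 days (on this read-out higher numbers stand for weaker inhibition and lower numbers for stronger inhibition), compound 1 `O=C(Nc1cc(C(F)(F)F)cc(C(F)(F)F)c1)c1ccc(-c2ccccc2)cc1O` gives 1580 nM. Two compounds built on a different core have also been measured: compound 3 `O=C(Nc1ccc(Cl)cc1)c1ccc2cccnc2c1O` gives 380 nM, and compound 2 `O=C(Nc1ccc(Cl)cc1Cl)c1ccc2cccnc2c1O` gives 450 nM. Within the data shown here, the one change from compound 3 to compound 2 is chloro in place of hydrogen on an aromatic carbon and it produced a 1.2-fold higher number from compound 3 to compound 2 (0.07 log units; within the scatter). How the core of compound 1 differs from the core of compound 3 is not broken down here. From the compounds shown here alone, compound 4 `O=C(Nc1cc(C(F)(F)F)cc(C(F)(F)F)c1)c1cc(Cl)c(-c2ccccc2)cc1O` is still untested; it arises from compound 1 by chloro in place of hydrogen on an aromatic carbon. This is the same kind of change, though the surroundings differ: here the chloro sits ortho to a phenyl group and para to a hydroxy group, whereas in compound 2 it sits ortho to a large group and meta to a chloro group. Compound 4 is expected to show a 1.1-fold lower number from compound 1 to compound 4 (0.05 log units; within the scatter) in this assay because the earlier step was a 1.2-fold higher number from compound 3 to compound 2 (0.07 log units; within the scatter). Compound 4 is therefore estimated at 1400 nM, with 600 nM and 3500 nM as the expected ends.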

Compound 4, half-maximal inhibitory concentration: 560 nM
The estimate for compound 4 lay 2.5-fold (0.40 log units) above the measured number, and the stated range ends above it.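

In this assay, placing chloro on the core of compound 1 gave a 2.8-fold lower number from compound 1 to compound 4 (0.45 log units; beyond the scatter). Among these compounds, the change therefore did not carry over from one core to the other with the same size of step: the same change on two cores in this assay, a 1.2-fold higher number (0.07 log units; within the scatter) from compound 3 to compound 2 and a 2.8-fold lower number (0.45 log units; beyond the scatter) from compound 1 to compound 4, 3.3-fold (0.52 log units) apart, beyond the scatter of two such steps With only one such pair on each core, this does not show what sets the two steps apart, whether the cores themselves or the different surroundings of the chloro, and it gives no rule for a third core.

From the compounds shown here alone, it remains open whether the lower number is particular to chloro or would also appear with a fluoro group, a methyl group or an amine at the same place, ortho to a phenyl group and para to a hydroxy group. Going by these compounds, whether chloro at other places on the core of compound 1 would give a similar step also remains open.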